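Methoxy Substitution Shifts Activity in a Glioma Cell Series

A few compounds are considered here, and "the series" means these few. Any claim that something is new, unique, unknown or untested is made for them only; others in the source may bear on it.

Measured so far:
Compound 1, `COc1ccc(-c2nc(SCC(=O)c3sc(-c4ccccc4)nc3C)[nH]c(=O)c2C#N)cc1`, gives 90.4% in a functional assay on U-87MG ATCC cells for antiproliferative activity against U-87 MG (Homo sapiens), read by MTT assay, with a stated time of 48 h, tested at 10 uM; on this read-out lower numbers stand for a stronger effect and higher numbers for a weaker effect at the one concentration tested.
Compound 2, `Cc1nc(-c2ccccc2)sc1C(=O)CSc1nc(-c2ccc(Cl)c(Cl)c2)c(C#N)c(=O)[nH]1`, gives 92.5% in this assay.
Compound 3, `COc1ccc(-c2nc(SCC(=O)c3sc(-c4ccccc4)nc3C)[nH]c(=O)c2C#N)cc1OC`, gives 69.8% in this assay.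

The cores of compound 1 and compound 2 differ by 3,4-dichlorophenyl in place of 4-methoxyphenyl on an aromatic carbon, and that change gives a number 2.1 percentage points higher from compound 1 to compound 2 (within the scatter). Compound 3 arises from compound 1 by methoxy in place of hydrogen on an aromatic carbon, a step of a number 20.6 percentage points lower from compound 1 to compound 3 (beyond the scatter). Compound 4, `COc1ccc(-c2nc(C)c(C(=O)CSc3nc(-c4ccc(Cl)c(Cl)c4)c(C#N)c(=O)[nH]3)s2)cc1`, is not yet measured; it arises from compound 2 by methoxy in place of hydrogen on an aromatic carbon. This is the same kind of change as from compound 1 to compound 3, but not the same: in compound 3 the methoxy sits ortho to a methoxy group and meta to a large group, whereas in compound 4 it sits para to a large group on another six-membered aromatic ring of carbon only. A smaller lowering is expected, a number 12.5 percentage points lower from compound 2 to compound 4 (beyond the scatter), because a number 20.6 percentage points lower from compound 1 to compound 3 (beyond the scatter) was made at a different place. Compound 4 is estimated at 80%, likely between 62% and 96%.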

Compound 4, a percentage reported as activity, at one concentration (the size of the read-out at that concentration, not a potency): 88.6%
Compound 4: the middle estimate sits 8.6 percentage points below what was measured; measured number inside the range.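

In this assay, methoxy in place of hydrogen gives a number 3.9 percentage points lower from compound 2 to compound 4 (within the scatter), so this step cannot be told apart from repeat-to-repeat variation. Set beside the earlier step, the same named change does not carry over at the same size from one core to the other: the same change on two cores in this assay, a number 20.6 percentage points lower (beyond the scatter) from compound 1 to compound 3 and a number 3.9 percentage points lower (within the scatter) from compound 2 to compound 4, 16.7 percentage points apart, beyond the scatter of two such steps What this does not show is whether the core or the place of the methoxy accounts for the gap, as the two steps differ in both.

The compounds shown leave open whether a methoxy at one matching place on both cores would give matching steps. They also leave open what an amine or a carboxylic acid would do on that same aromatic carbon.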